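A Bromo for Chloro Swap at the Assay Limit

The compounds below may be only part of what the source reports. "The series", "measured", "known", "first", "only" and "open" are said of these compounds alone.

Compound 1 `Nc1c(C2=NCCN2)cnn1-c1ccccc1` was tested in an ADME assay on Vero cells (Chlorocebus sabaeus) for cytotoxicity, read by CellTiter-Glo and ATP content, with a stated time of 72 h; on this read-out higher numbers stand for lower toxicity in this test and lower numbers for higher toxicity in this test. In this assay compound 1 gives > 500000 nM, which is a limit of the assay and not a number. Compound 2 `Nc1c(C2=NCCN2)cnn1-c1cccc(Cl)c1` gives > 500000 nM, which is also a limit and not a number. Compound 2 therefore has no exact standing, and the record so far is the limit of > 500000 nM in this assay, at which 2 of the 2 values shown sit.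

Compound 3 `Nc1c(C2=NCCN2)cnn1-c1cccc(Br)c1` carries bromo in place of chloro on an aromatic carbon, meta to a large group, and the shared core is otherwise unchanged: bromo in place of chloro on an aromatic carbon. Among the measured compounds shown here, the one measured step that bears on this change is a step that the two limits leave unreadable from compound 1 to compound 2. It offers no size to carry over, so no step beyond the scatter is expected in this assay, in either direction. The expected change is a number no higher from compound 2 to compound 3 (the limit leaves the size open). Compound 3 is estimated at 500000 nM, with an expected range from 250000 nM to 700000 nM. The assay may well report only a limit again.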

Compound 3, half-maximal cytotoxic concentration: 352000 nM
For compound 3 the middle estimate is 1.4-fold (0.15 log units) above the measured one; low and high end bracket the measured number.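

In this assay compound 3 is the first of the compounds shown to give a number and not a limit, so a measured value is now on record for a halogen on this aromatic carbon, meta to a large group. Bromo in place of chloro gives an at least 1.4-fold lower number from compound 2 to compound 3 (0.15 log units; that floor lies within the scatter), and bromo in place of hydrogen gives an at least 1.4-fold lower number from compound 1 to compound 3 (0.15 log units; that floor lies within the scatter); each is only a floor, so neither change is shown to go beyond the usual scatter, though the true size of either could be larger. The other two compounds offer no exact number to set against compound 3: the limit of > 500000 nM in this assay, at which 2 of the 3 values shown sit.

What the compounds shown leave open is how far the numbers for the hydrogen and chloro compounds actually lie from that of the bromo compound, and so whether bromo differs from chloro at all in this test. They also leave open how other groups on this aromatic carbon, such as a methyl, a methoxy, a nitrile or a carboxylic acid, would read here, and whether iodo would continue any trend from chloro to bromo.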